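From Difluorophenyl to Trifluoromethylphenyl: an Expected Cell Result

This account rests on a few compounds, and the source may have more. Where it says the series, first, only, none or still open, it means among the compounds named here.

Compound 1 `CN(C(=O)NC(=O)c1ccc([N+](=O)[O-])cc1)c1nc(C(F)(F)F)c(C(=O)N/N=C/c2ccc([N+](=O)[O-])cc2)s1`: 8.98 ug/mL
Compound 2 `CN(C(=O)NC(=O)c1ccc(F)c(F)c1)c1nc(C(F)(F)F)c(C(=O)N/N=C/c2cc(C(F)(F)F)cc(C(F)(F)F)c2)s1`: 5.47 ug/mL

Of the compounds shown here, two have been tested in a functional assay on A549 cells (Homo sapiens) for inhibition, read by MTT assay, with a stated time of 72 h; on this read-out higher numbers stand for weaker inhibition and lower numbers for stronger inhibition. Compound 1 gives 8.98 ug/mL in this assay, and compound 2 gives 5.47 ug/mL. Compound 2 holds the lower of the two numbers, but the gap to compound 1 lies within the usual scatter, so the two cannot be told apart.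

Compound 3 `CN(C(=O)NC(=O)c1ccc(C(F)(F)F)cc1)c1nc(C(F)(F)F)c(C(=O)N/N=C/c2cc(C(F)(F)F)cc(C(F)(F)F)c2)s1` differs from compound 2 in one place: 4-(trifluoromethyl)phenyl in place of 3,4-difluorophenyl on a carbonyl carbon. Going by the values given here, no measured pair shows this exact change. Compound 1 at 8.98 ug/mL and compound 2 at 5.47 ug/mL already carry different groups on this carbonyl yet read alike. The step from compound 2 to compound 3 is therefore expected to be a 1.0-fold higher number from compound 2 to compound 3 (0.00 log units; within the scatter), nothing beyond the scatter, in no clear direction. Compound 3 is expected to give 5.5 ug/mL, within a range of 2.7 ug/mL to 11 ug/mL.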

Compound 3, half-maximal inhibitory concentration: 5.9 ug/mL
Beside the measured number, compound 3's estimate is 1.1-fold (0.03 log units) below it; measured number inside the range.
By their numbers in this assay, from the lowest: compounds 2, 3 and 1 (each within the scatter of the next).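

Going by these compounds alone, compounds 2 and 3 are the first pair here that differs in one place only, so the group on this carbonyl carbon can now be judged on its own. In this assay the swap of 3,4-difluorophenyl for 4-(trifluoromethyl)phenyl, a group of 10 heavy atoms in place of one of 8, gives a 1.1-fold higher number from compound 2 to compound 3 (0.03 log units; within the scatter) and so leaves the two compounds impossible to tell apart. No measurement on hand offers a reason for this result.

As far as these compounds go, both groups in this pair are fluorine-bearing phenyl rings, so it stays open whether this position would read alike with a group of another kind, such as a phenyl ring carrying an amine or a carboxylic acid, or a plain alkyl chain. Compound 1 differs from both in more than one place, so it cannot show what its nitro-bearing ring does at this carbonyl alone.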